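Sulfonyl Aryl Exchange in an N-Type Calcium Channel Series

The source may hold more compounds than are shown below. What is called first, only, known or untested is meant among the compounds shown, and "the series" means these compounds.

Compound 1, `O=C(c1ccccc1)N1CCC(N(C2CC2)S(=O)(=O)c2cccc(C(F)(F)F)c2)CC1`: 42%
Compound 2, `CS(=O)(=O)c1cccc(S(=O)(=O)N(C2CC2)C2CCN(C(=O)c3cc(F)ccc3S(C)(=O)=O)CC2)c1`: 0%
Compound 3, `NC(=O)c1ccc(C(=O)N2CCC(N(C3CC3)S(=O)(=O)c3cccc(C(F)(F)F)c3)CC2)cc1`: 12%

In an assay on HEK293 cells for inhibition of Voltage-dependent N-type calcium channel subunit alpha-1B (Homo sapiens), read by FLIPR and calcium flux, tested at 1 uM (a higher number here means more inhibition at the concentration tested (going by the name of the read-out), a lower number less inhibition), compound 1 gives 42%, compound 3 gives 12%, and compound 2 gives 0%. Compound 2 stands lowest of the three, beyond the scatter from both others. Among the compounds with values here, the only one-place step measured is a number 30 percentage points lower from compound 1 to compound 3 (beyond the scatter), which changes the benzoyl side rather than the sulfonyl aryl group.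

Compound 4, `CS(=O)(=O)c1ccc(F)cc1C(=O)N1CCC(N(C2CC2)S(=O)(=O)c2ccc(OC(F)(F)F)cc2)CC1`, is not yet measured. The change from compound 2 is 4-(trifluoromethoxy)phenyl in place of 3-(methylsulfonyl)phenyl on a sulfonyl sulfur. Within the data shown here, no measured step touches this position, so the sulfonyl aryl exchange has no direct precedent here; compound 1 and compound 2 differ at that aryl group but also on the benzoyl side, so their values show only that the two compounds lie far apart. Given that compound 2 sits at the floor of the read-out, a move upward is plausible but uncertain; for compound 4 the expected step is a number 15 percentage points higher from compound 2 to compound 4 (beyond the scatter). Compound 4 is estimated at 15%, within 0% to 40%.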

Compound 4, a percentage reported as inhibition, at one concentration (the size of the read-out at that concentration, not a potency): 0%
Compound 4: middle estimate off by 15 percentage points, on the high side; measured number inside the range.
By their numbers in this assay, from the lowest: compounds 2 and 4 (each within the scatter of the next); then compound 3; then compound 1.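

Within the data shown here, this is the first direct reading at the sulfonyl sulfur: in this assay, 4-(trifluoromethoxy)phenyl in place of 3-(methylsulfonyl)phenyl gives no change at the digits printed from compound 2 to compound 4 (within the scatter). With the benzoyl side held constant, this exchange therefore does not lift the number, and the low value of compound 2 cannot be tied to 3-(methylsulfonyl)phenyl alone. No measurement on hand accounts for this result.

With compound 2 and compound 4 both at the bottom of the read-out, the step cannot show how these two aryl groups would compare on a benzoyl side that leaves measurable inhibition. Going by these compounds, how this position would respond on that benzoyl side to a phenyl ring bearing a carboxylic acid or an amine also remains open.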